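The source may report more compounds than this note shows. Statements on the series, on what has been measured and on what is new or still open speak of the compounds shown alone.

In an ADME assay on HepG2 2.2.15 cells (Homo sapiens) for cytotoxicity (a higher number here means that more compound is tolerated, a lower number that less compound is tolerated), compound 1 `CC(C)[C@H](N)C(=O)OC1CCN(S(=O)(=O)c2cc(C(=O)Nc3cc(F)c(F)c(F)c3)ccc2F)CC1` gives > 10000 nM, which is a limit of the assay rather than a measured number. Compound 2 `CCC(C)[C@H](N)C(=O)OC1CCN(S(=O)(=O)c2cc(C(=O)Nc3cc(F)c(F)c(F)c3)ccc2F)CC1` gives > 10000 nM, also a limit. Compound 3 `CC(C)C[C@H](N)C(=O)OC1CCN(S(=O)(=O)c2cc(C(=O)Nc3cc(F)c(F)c(F)c3)ccc2F)CC1` gives 5770 nM. The first two values rest on (the limit of > 10000 nM in this assay, at which 2 of the 3 values shown sit). Compound 3 shows an at least 1.7-fold lower number from compound 1 to compound 3 (0.23 log units; that floor lies within the scatter) and an at least 1.7-fold lower number from compound 2 to compound 3 (0.23 log units; that floor lies within the scatter), both only floors within the scatter, while a step that the two limits leave unreadable from compound 1 to compound 2 remains. Compound 4 `C[C@H](N)C(=O)OC1CCN(S(=O)(=O)c2cc(C(=O)Nc3cc(F)c(F)c(F)c3)ccc2F)CC1` differs from compound 1 by methyl in place of isopropyl on a saturated chain carbon bound to an amine nitrogen and a carbonyl carbon. All measured steps alter this same side chain without a readable change, so for compound 4 no step beyond the scatter is expected and the value is estimated at 12000 nM, within a range from 5000 nM to 30000 nM. This expectation corresponds to a step that the limit leaves unreadable from compound 1 to compound 4.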

Compound 4, half-maximal cytotoxic concentration: 4810 nM
Estimate against measurement, compound 4: 2.5-fold (0.40 log units) above, outside the stated range (below it).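

In this assay, a change at this position on the saturated chain carbon now reads beyond the scatter, with an at least 2.0-fold lower number from compound 1 to compound 4 (0.31 log units; beyond the scatter) and an at least 2.0-fold lower number from compound 2 to compound 4 (0.31 log units; beyond the scatter). Compound 3, with isobutyl, goes against any simple order by side chain size, as there is a 1.2-fold lower number from compound 3 to compound 4 (0.08 log units; within the scatter). The two steps beyond the scatter are only floors, because compound 1 and compound 2 rest on a limit: the limit of > 10000 nM in this assay, at which 2 of the 4 values shown sit.

Going by these compounds, the true size of those two steps stays open. So does the effect on tolerated concentration of a side chain carrying a carboxylic acid or a second amine.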